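Para Substituent Swap: Methyl Replaces Chloro

A few compounds are considered here, and "the series" means these few. Any claim that something is new, unique, unknown or untested is made for them only; others in the source may bear on it.

Measured so far:
- compound 1, `Fc1ccc(C2=NN(C3=NC(c4ccccc4)CS3)C(c3cccc4ccccc34)C2)cc1`, 23200 nM
- compound 2, `Cc1ccc(C2=NN(C3=NC(=O)CS3)C(c3cccc4ccccc34)C2)cc1`, 8660 nM
- compound 3, `Clc1ccc(C2=NN(C3=NC(c4ccccc4)CS3)C(c3cccc4ccccc34)C2)cc1`, 18700 nM

In a functional assay on HepG2 cells (Homo sapiens) for inhibition, read by CCK-8 assay, with a stated time of 48 h (a higher number here means a weaker inhibitor, a lower number a stronger inhibitor), compound 3 gives 18700 nM. Among the three numbers shown, compound 3 has the second highest; its nearest neighbour is compound 1, which gives 23200 nM, and the two lie within the scatter of each other. Compound 2 gives 8660 nM, a lower number that lies beyond the scatter from compound 3, but compound 2 carries a carbonyl on the shared core where compounds 1 and 3 carry a phenyl, so it does not isolate the change at hand.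

Compound 4, `Cc1ccc(C2=NN(C3=NC(c4ccccc4)CS3)C(c3cccc4ccccc34)C2)cc1`, differs from compound 3 in one place: methyl in place of chloro on an aromatic carbon. Within the data shown here, the only measured step on the same position is a 1.2-fold lower number from compound 1 to compound 3 (0.09 log units; within the scatter), which shows that swapping one small para group for another left this assay essentially unchanged. Compound 4 is therefore expected to show a 1.2-fold lower number from compound 3 to compound 4 (0.07 log units; within the scatter), no shift beyond the scatter.

The estimate for compound 4 in this assay is 16000 nM, within 7000 nM to 36000 nM.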

Compound 4, half-maximal inhibitory concentration: 10400 nM
Compound 4: middle estimate off by 1.5-fold (0.19 log units), on the high side; the measured number falls inside the stated range.
By their numbers in this assay, from the lowest: compounds 2, 4, 3 and 1 (each within the scatter of the next, the first and the last beyond it).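

In this assay, methyl in place of chloro gives a 1.8-fold lower number from compound 3 to compound 4 (0.25 log units; within the scatter) and so stays within the scatter, as the earlier step from fluoro to chloro did. Among these compounds, the first change at this position to go beyond the scatter, though only modestly, is methyl in place of fluoro, with a 2.2-fold lower number from compound 1 to compound 4 (0.35 log units; beyond the scatter); chloro lies within the scatter of both groups, so only the two ends of this small series can be told apart. Among the compounds shown here, with methyl held constant, the larger group on the ring amine nitrogen gives a 1.2-fold higher number from compound 2 to compound 4 (0.08 log units; within the scatter), which shows no separation between that pair.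

Nothing available explains these differences. Also open, going by these compounds, is how a methoxy group, an amine or a carboxylic acid at this position would read in this assay.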